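A few compounds are considered here, and "the series" means these few. Any claim that something is new, unique, unknown or untested is made for them only; others in the source may bear on it.

Compound 1 `COc1ccc(C2=C(c3cc(OC)c(OC)c(OC)c3)C(=O)C(O)C2)cc1NC(=O)c1ccccc1`: > 100 ug/mL
Compound 2 `COc1ccc(C2=C(c3cc(OC)c(OC)c(OC)c3)C(=O)CC2O)cc1O`: 8 ug/mL

In an ADME assay on DU-145 cells (Homo sapiens) for cytotoxicity, read by MTT assay, with a stated time of 72 h (a lower number here means a stronger inhibitor, a higher number a weaker inhibitor), compound 1 is reported only as a limit of the assay, > 100 ug/mL. Compound 2 gives 8 ug/mL in this assay, a clearly stronger result. Compound 1 therefore stands at the limit of > 100 ug/mL in this assay, at which 1 of the 2 values shown sits, so no number, only a limit, is known for it. The change leading to compound 3 `COc1ccc(C2=C(c3cc(OC)c(OC)c(OC)c3)C(=O)C(O)C2)cc1OC(C)C` is isopropoxy in place of benzamido on an aromatic carbon. Among the compounds with values here, no step between measured compounds covers this exchange, and compound 2 differs from compound 1 in more than one place, so the size of the step cannot be read from the data. The expected step of an at least 3.3-fold lower number from compound 1 to compound 3 (0.52 log units; beyond the scatter) is toward stronger inhibition, likely beyond the scatter, though with wide uncertainty. For compound 3 the estimated value in this assay is 30 ug/mL, within a range from 5 ug/mL to 100 ug/mL.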

Compound 3, half-maximal inhibitory concentration: > 100 ug/mL
Compound 3 ended at the assay's limit (the forecaster's own chance of this, stated with the estimate: 30%); middle value at least 3.3-fold (0.52 log units) away from the limit.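

Compound 1 and compound 3 both stand at a limit of the assay, not at a number, so no step between them can be read in this assay: the limit of > 100 ug/mL in this assay, at which 2 of the 3 values shown sit.

The compounds shown leave open whether isopropoxy in place of benzamido changes the result at all.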